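Removing one methoxy group from an inactive thiourea-type compound

The source may report more compounds than this note shows. Statements on the series, on what has been measured and on what is new or still open speak of the compounds shown alone.

Measured so far:
- compound 1, `COc1cc(C2=CC(c3cc(OC)c(OC)c(OC)c3)NC(=S)N2)cc(OC)c1OC`: > 100000 nM
- compound 2, `COc1cc(OC)c(C2C=C(c3cc(OC)c(OC)c(OC)c3)NC(=S)N2)c(OC)c1`: 5700 nM

Compound 1 gives only a limit in a functional assay on L1210 cells (Mus musculus) for cytotoxicity, read by MTT assay, with a stated time of 72 h; on this read-out lower numbers stand for stronger inhibition and higher numbers for weaker inhibition: the limit of > 100000 nM in this assay, at which 1 of the 2 values shown sits, so its true value is not known as a number. Compound 2 carries the same set of methoxy groups in a different arrangement and reaches 5700 nM in this assay. Within the data shown here, no step between these two compounds is given, so their two values can only be set side by side.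

Compound 3, `COc1ccc(C2C=C(c3cc(OC)c(OC)c(OC)c3)NC(=S)N2)cc1OC`, differs from compound 1 by hydrogen in place of methoxy on an aromatic carbon. Because compound 1 shows only > 100000 nM, no direction can be fixed for this change. Compound 3 is therefore expected to land at 60000 nM, within 8000 nM to 200000 nM, a step of an at least 1.6-fold lower number from compound 1 to compound 3 (0.22 log units; that floor lies within the scatter) that stays close to the scatter, with a real chance that this assay again reports only a limit.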

Compound 3, half-maximal inhibitory concentration: 56300 nM
Beside the measured number, compound 3's estimate is 1.1-fold (0.03 log units) above it; measured number inside the range.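

Compound 1 stands only at a limit, not at a number: the limit of > 100000 nM in this assay, at which 1 of the 3 values shown sits.

Hydrogen in place of methoxy on this aromatic carbon, ortho to a methoxy group and meta to a large group, gives an at least 1.7-fold lower number from compound 1 to compound 3 (0.24 log units; that floor lies within the scatter). That figure is only a floor, so the true step may be small or much larger, but the change does show that compound 3 gives a measurable value in this assay without the methoxy group at this position.

The compounds shown leave open whether the step truly exceeds the scatter, and whether hydrogen itself matters or the methoxy group merely has to leave. A hydroxyl group, a fluorine atom or an amine on the same carbon would help separate these two readings.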